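The compounds below may be only part of what the source reports. "The series", "measured", "known", "first", "only" and "open" are said of these compounds alone.

For the measured compounds named here, compound 2, whose structure is `COc1cc(-c2nn(-c3cccc(NC(=O)Nc4cccc(C(F)(F)F)c4)c3)cc2-c2ccncc2)ccc1Cl`, is the only compound here with a number rather than a limit in a functional assay on 786-0 cells (Homo sapiens) for inhibition, read by sulforhodamine B assay, with a stated time of 48 h (on this read-out higher numbers stand for weaker inhibition of growth and lower numbers for stronger inhibition of growth), where compound 2 gives 4050 nM. Its companion, compound 1 with the structure `COc1cc(-c2nn(-c3cccc(NC(=O)c4cccc(C(F)(F)F)c4)c3)cc2-c2ccncc2)ccc1Cl`, carries an amide in place of the urea of compound 2. In this assay compound 1 reaches only a limit, > 50000 nM; this is the limit of > 50000 nM in this assay, at which 1 of the 2 values shown sits. Going from the amide of compound 1 to the urea of compound 2 gives an at least 12-fold lower number from compound 1 to compound 2 (1.09 log units; beyond the scatter).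

Compound 3, with the structure `COc1cc(-c2nn(-c3cccc(NC(=O)c4ccc(Cl)c(C(F)(F)F)c4)c3)cc2-c2ccncc2)ccc1Cl`, has not been measured. Relative to compound 2 the change is 4-chloro-3-(trifluoromethyl)phenyl in place of (3-(trifluoromethyl)phenyl)amino on a carbonyl carbon. This undoes the urea-for-amide exchange that set compound 1 apart from compound 2, while also placing a chlorine on the ring. Going by the values given here, only the step from compound 1 to compound 2 bears on it, and that step was large and beyond the scatter, in favour of the urea. A return to the amide is therefore expected to weaken growth inhibition markedly, so compound 3 is expected to give a 7.4-fold higher number from compound 2 to compound 3 (0.87 log units; beyond the scatter). The estimate for compound 3 is 30000 nM, between 8000 nM and 100000 nM, with a real chance that this assay again reports only a limit.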

Compound 3, concentration for total growth inhibition: > 32500 nM
Compound 3 was reported as a limit; the forecaster's own chance of this, stated with the estimate: 50%; middle value at least 1.0-fold (0.03 log units) from the limit.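

Compound 3 also ends at a limit rather than a number: the limit of > 32500 nM in this assay, at which 1 of the 3 values shown sits. Even so, a second amide now falls clearly on the weaker side of the urea of compound 2, with an at least 8.0-fold higher number from compound 2 to compound 3 (0.90 log units; beyond the scatter), so among the three compounds shown, only the urea gives a number in this assay, and neither amide does. The added chloro did not bring the amide back to a number, but the step from compound 1 to compound 3 cannot be read because both values are limits, so the chloro could have helped, harmed or done nothing within that range.

Since the step from compound 2 to compound 3 swaps the amino nitrogen and adds the chloro together, the compounds shown cannot say how much each change contributes, and a urea carrying the 4-chloro-3-(trifluoromethyl)phenyl ring would separate the two. As far as these compounds go, it also remains open what a carbamate, with an oxygen in place of the amino nitrogen, or a urea with a methyl on that nitrogen would give at this position.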